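Stereochemical inversion in a series of tetramic acid analogues

The source may report more compounds than this note shows. Statements on the series, on what has been measured and on what is new or still open speak of the compounds shown alone.

Working notes on the series, which is tested in a functional assay on Bel-7402 cells (Homo sapiens) for inhibition, read by MTT assay, with a stated time of 24 h; on this read-out higher numbers stand for weaker inhibition and lower numbers for stronger inhibition. Compound 1 `CCCCCCC(C)/C(O)=C1\C(=O)[C@@H]([C@@H](C)O)N(C)C1=O` carries a saturated chain at the enol. In this assay compound 1 gives only a limit, > 100000 nM. Compound 2 `C/C=C1/C(=O)/C(=C(/O)C(C)CCCCCC)C(=O)N1C` bears an ethylidene on the ring. Compound 2 likewise returns a limit, > 100000 nM. Compound 3 `C/C=C/CCCC(C)/C(O)=C1\C(=O)[C@H]([C@H](C)O)N(C)C1=O` carries an unsaturated chain and the hydroxyethyl group on the ring. In this assay compound 3 also gives a limit and no number, > 100000 nM. Compound 3 therefore stands nowhere distinct on the numbers: its own value is a limit, and the two further values shown are limits as well, all three sitting at the same place (the limit of > 100000 nM in this assay, at which 3 of the 3 values shown sit). Within the data shown here, no pair of measured compounds differs in a single place, so no measured step tells how any one change moves the read-out.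

Compound 4 `C/C=C/CCCC(C)/C(O)=C1\C(=O)[C@@H]([C@@H](C)O)N(C)C1=O` is the next to be measured. Against compound 3 the change is the two compounds have the same atoms and bonds; at least one stereo element is drawn with a configuration in one of them and without one in the other: 2 of 5 stereo elements differ; a stereocentre at a saturated ring carbon is drawn S in compound 3 and R in compound 4; a stereocentre at a saturated chain carbon is drawn S in compound 3 and R in compound 4. Since compound 3 shows only a limit > 100000 nM, the step to compound 4 is expected to be none beyond the scatter, a step that the limit leaves unreadable from compound 3 to compound 4. Compound 4 is expected to give 150000 nM, with a range from 50000 nM to 500000 nM, and most probably again only a limit.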

Compound 4, half-maximal inhibitory concentration: > 100000 nM
Compound 4 was reported as a limit (the forecaster's own chance of this, stated with the estimate: 85%); the middle value lies beyond the limit too.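

In this assay, among these compounds, compound 4 gives only the limit > 100000 nM and so no step to it from compound 3 or compound 1 can be read. The compounds shown leave open whether inverting the two stereocentres or changing the chain moves the read-out at all, with every value at one place: the limit of > 100000 nM in this assay, at which 4 of the 4 values shown sit.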